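Swapping Anilino for Ethylamino on the Shared Core

The source may hold more compounds than are shown below. What is called first, only, known or untested is meant among the compounds shown, and "the series" means these compounds.

Compound 1 `N#Cc1c(O)nc(SCc2nc3ccccc3[nH]2)nc1-c1ccccc1`: 7.7 nM
Compound 2 `N#Cc1c(Nc2ccccc2)nc(SCc2nc3ccccc3[nH]2)nc1-c1ccccc1`: 8.9 nM

In a functional assay on SK-MEL-28 cells (Homo sapiens) for cytotoxicity, read by MTT assay, with a stated time of 3 days (a lower number here means a stronger inhibitor, a higher number a weaker inhibitor), compound 2 gives 8.9 nM. This lies within the usual scatter of compound 1 at 7.7 nM, so the two cannot be told apart. Compound 3 `CCNc1nc(SCc2nc3ccccc3[nH]2)nc(-c2ccccc2)c1C#N` has not yet been measured. It differs from compound 2 by ethyl in place of phenyl on a nitrogen on an aromatic ring, which turns anilino into ethylamino: ethyl in place of phenyl on a nitrogen on an aromatic ring. Going by the values given here, only one measured step bears on this place: a 1.2-fold higher number from compound 1 to compound 2 (0.06 log units; within the scatter). There, anilino replaced hydroxy and the number stayed within the scatter. A single step is thin evidence, but it gives no reason to expect a change beyond the scatter in this assay. The estimated step is a 1.1-fold higher number from compound 2 to compound 3 (0.05 log units; within the scatter). Compound 3 is expected at 10 nM, with an estimated range of 3 nM to 35 nM.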

Compound 3, half-maximal inhibitory concentration: 5.3 nM
Compound 3: middle estimate off by 1.9-fold (0.28 log units), on the high side; the measured number falls inside the stated range.
By their numbers in this assay, from the lowest: compounds 3, 1 and 2 (each within the scatter of the next).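

In this assay, replacing the phenyl with ethyl on this nitrogen gives a 1.7-fold lower number from compound 2 to compound 3 (0.23 log units; within the scatter), so losing the ring from this group leaves the number within the scatter. Compared with hydroxy on the same aromatic carbon, ethylamino gives a 1.5-fold lower number from compound 1 to compound 3 (0.16 log units; within the scatter), which means hydroxy, anilino and ethylamino cannot be told apart at this place in this cell assay. Nothing measured here explains why these three groups read alike.

As far as these compounds go, it remains open whether a longer chain such as hexylamino, or a group such as a carboxylic acid or a dimethylamino group, would also stay within the scatter at this place. All three compounds share the rest of the core, so they say nothing about changes made elsewhere on it.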